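Swapping Methoxy for Methylsulfanyl on Compound 3

This account rests on a few compounds, and the source may have more. Where it says the series, first, only, none or still open, it means among the compounds named here.

Of the compounds shown here, three sharing one core have been measured so far in a functional assay on HeLa cells (Homo sapiens) for cytotoxicity, read by sulforhodamine B assay; a lower number here means a stronger inhibitor, a higher number a weaker inhibitor. There, compound 1 `COc1ccc(N(C)c2nc(C)nc3ccccc23)cc1` gives 1.5 nM, compound 2 `CSc1ccc(N(C)c2nc(C)nc3ccccc23)cc1` gives 1.1 nM, and compound 3 `COc1ccc(N(C)c2ncnc3ccccc23)cc1` gives 7.4 nM. Compound 3 has the highest number of the three, which makes it the weakest inhibitor of this small set.

The next compound, compound 4 `CSc1ccc(N(C)c2ncnc3ccccc23)cc1`, differs from compound 3 in one place: methylsulfanyl in place of methoxy on an aromatic carbon. In words, this is methylsulfanyl in place of methoxy on an aromatic carbon, para to a large group.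

The same swap has been measured once already, and it gave a 1.4-fold lower number from compound 1 to compound 2 (0.13 log units; within the scatter), a change within the scatter. The other measured step, a 4.9-fold higher number from compound 1 to compound 3 (0.69 log units; beyond the scatter), is beyond the scatter, but it is a different change, hydrogen in place of methyl on an aromatic carbon, and compound 4 keeps that hydrogen. That step therefore sets the starting level and says little about the swap itself. A single precedent is thin evidence, so the range must stay wide.

The estimated step is small, a 1.3-fold lower number from compound 3 to compound 4 (0.13 log units; within the scatter), and no change beyond the scatter is expected in this assay. For compound 4 the expected value is 5.5 nM, with an estimated range from 2.5 nM to 12 nM.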

Compound 4, half-maximal inhibitory concentration: 7.3 nM
Estimate against measurement, compound 4: 1.3-fold (0.12 log units) below, within the range that was stated.
By their numbers in this assay, from the lowest: compounds 2 and 1 (each within the scatter of the next); then compounds 4 and 3 (each within the scatter of the next).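

In this assay, the swap of methoxy for methylsulfanyl, on an aromatic carbon para to a large group, now has a second reading, a 1.0-fold lower number from compound 3 to compound 4 (0.01 log units; within the scatter), so it stays within the scatter with or without the methyl on the shared core, and the two readings agree: the same change on two cores in this assay, a 1.4-fold lower number (0.13 log units; within the scatter) from compound 1 to compound 2 and a 1.0-fold lower number (0.01 log units; within the scatter) from compound 3 to compound 4, 1.3-fold (0.13 log units) apart, within the scatter of two such steps. The hydrogen-for-methyl change also has a second reading, a 6.6-fold higher number from compound 2 to compound 4 (0.82 log units; beyond the scatter), and it lies beyond the scatter with either methoxy or methylsulfanyl in place, again at a matching size: the same change on two cores in this assay, a 4.9-fold higher number (0.69 log units; beyond the scatter) from compound 1 to compound 3 and a 6.6-fold higher number (0.82 log units; beyond the scatter) from compound 2 to compound 4, 1.3-fold (0.13 log units) apart, within the scatter of two such steps. Across these four compounds, the two changes therefore behave independently: the methyl separates the compounds into two pairs, while the choice between methoxy and methylsulfanyl does not separate them, and no compound here goes against this.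

Among these compounds, these results cover only two closely matched groups at this position, so an amine, a carboxylic acid or a longer chain such as butoxy could behave quite differently. At the other changed place, only hydrogen and methyl appear, which leaves ethyl or trifluoromethyl open.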